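The compounds below may be only part of what the source reports. "The series", "measured", "known", "first", "only" and "open" are said of these compounds alone.

Measured compounds in the series:

Compound 1, `CCCCCCCCCCCCNC(=O)[C@@H](NC(=O)c1nccc2ccccc12)[C@@H](C)O` — 50500 nM
Compound 2, `CCCCCCCCCCCCNC(=O)[C@@H](NC(=O)c1cc2ccccc2[nH]1)[C@@H](C)O` — 12300 nM
Compound 3, `CCCCCCCCCCCCCCCCCCNC(=O)[C@@H](NC(=O)c1nccc2ccccc12)[C@@H](C)O` — 30800 nM

All three were run in a functional assay on MCF7 cells (Homo sapiens) for cytotoxicity, read by MTT assay, with a stated time of 48 h; a lower number here means a stronger inhibitor, a higher number a weaker inhibitor. Compound 1 gives 50500 nM, compound 2 gives 12300 nM and compound 3 gives 30800 nM in this assay.

Two changes have been made from compound 1. The first, (1H-indol-2-yl in place of isoquinolin-1-yl on a carbonyl carbon), gives a 4.1-fold lower number from compound 1 to compound 2 (0.61 log units; beyond the scatter). The second, (hexyl in place of hydrogen on a saturated chain carbon, ten or more bonds along the chain from an amide-type nitrogen), gives a 1.6-fold lower number from compound 1 to compound 3 (0.21 log units; within the scatter), so compound 1 and compound 3 cannot be ordered on this evidence. The values of compound 2 and compound 3 differ beyond the scatter, compound 2 showing the lower number.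

Compound 4, `CCCCCCCCCCCCCCCCCCNC(=O)[C@@H](NC(=O)c1cc2ccccc2[nH]1)[C@@H](C)O`, is not yet measured. It differs from compound 3 by 1H-indol-2-yl in place of isoquinolin-1-yl on a carbonyl carbon. Within the data shown here, this is the same change as the one from compound 1 to compound 2, with the same surroundings at the place of exchange; the two cores differ by hexyl in place of hydrogen on a saturated chain carbon, ten or more bonds along the chain from an amide-type nitrogen. The change has been seen once, where it gave a 4.1-fold lower number from compound 1 to compound 2 (0.61 log units; beyond the scatter).

Among the measured compounds shown here, for compound 4 the step from compound 3 is expected to be a 4.1-fold lower number from compound 3 to compound 4 (0.61 log units; beyond the scatter), resting on the one prior instance, because a 4.1-fold lower number from compound 1 to compound 2 (0.61 log units; beyond the scatter) was the only measured case. The other measured change, a 1.6-fold lower number from compound 1 to compound 3 (0.21 log units; within the scatter), stayed within the scatter. Compound 4 is therefore estimated at 7500 nM in this assay, with a likely range from 3000 nM to 20000 nM. The estimate rests on a single precedent and a short series, and its width reflects that.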

Compound 4, half-maximal inhibitory concentration: 35700 nM
For compound 4 the middle estimate is 4.8-fold (0.68 log units) below the measured one; the measured number lies above the stated range.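

Working notes on the series: in this assay, 1H-indol-2-yl in place of isoquinolin-1-yl on a carbonyl carbon gave a 1.2-fold higher number from compound 3 to compound 4 (0.06 log units; within the scatter) and so did not repeat on the core of compound 3 what it had done on the core of compound 1: the same change on two cores in this assay, a 4.1-fold lower number (0.61 log units; beyond the scatter) from compound 1 to compound 2 and a 1.2-fold higher number (0.06 log units; within the scatter) from compound 3 to compound 4, 4.8-fold (0.68 log units) apart, beyond the scatter of two such steps.

Read along the other edge of the same four compounds, hexyl in place of hydrogen on the chain gave a 2.9-fold higher number from compound 2 to compound 4 (0.46 log units; beyond the scatter) with 1H-indol-2-yl on the carbonyl carbon, which does not match its step with isoquinolin-1-yl: the same change on two cores in this assay, a 1.6-fold lower number (0.21 log units; within the scatter) from compound 1 to compound 3 and a 2.9-fold higher number (0.46 log units; beyond the scatter) from compound 2 to compound 4, 4.8-fold (0.68 log units) apart, beyond the scatter of two such steps.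

The two changes therefore do not add up independently in this set, and a step measured on one of these cores is a poor guide to the other; however, this rests on one square of four compounds, so it shows neither why the steps differ nor a rule that would hold beyond them.

Still open, on these data alone, is how the exchange behaves at other chain lengths, for example a shorter chain such as octyl, or with an amine or a carboxylic acid at the chain end. Also open, as far as these compounds go, is whether other groups on the carbonyl carbon, such as phenyl or quinolin-2-yl, would follow 1H-indol-2-yl or isoquinolin-1-yl on either core.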